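Replacing a Dichlorobenzyl Ether with a Fluorobenzyl Ether

The source may report more compounds than this note shows. Statements on the series, on what has been measured and on what is new or still open speak of the compounds shown alone.

Compound 1 `Cc1ccc(NC(=S)NC(=O)c2ccc(OCc3cccc(F)c3)cc2)cc1-c1nc2ccccc2[nH]1` in a functional assay on SW-620 cells (Homo sapiens) for inhibition, read by MTT assay, with a stated time of 48 h (on this read-out lower numbers stand for stronger inhibition and higher numbers for weaker inhibition), gives > 100000 nM, which is a limit of the assay and not a number.
Compound 2 `Cc1ccc(NC(=S)NC(=O)c2ccc(OCc3ccc(Cl)c(Cl)c3)cc2)cc1-c1nc2ccccc2[nH]1` gives 30700 nM in this assay.

Compound 2 therefore carries the only actual number shown in this assay, the other value being a limit (the limit of > 100000 nM in this assay, at which 1 of the 2 values shown sits). Compound 3 `Cc1ccc(NC(=S)NC(=O)c2ccc(OCc3ccc(F)cc3)cc2)cc1-c1nc2ccccc2[nH]1` differs from compound 2 in one place: 4-fluorophenyl in place of 3,4-dichlorophenyl on a saturated chain carbon bound to an oxygen on an aromatic ring. Among the measured compounds shown here, the one measured step that bears on this change is an at least 3.2-fold lower number from compound 1 to compound 2 (0.51 log units; beyond the scatter), where a fluorophenyl group was exchanged for the 3,4-dichlorophenyl group that compound 3 now gives up again. Compound 3 moves back toward a fluorophenyl group, and the expectation is accordingly a step in the opposite direction, with a higher number in this assay, estimated at a 2.6-fold higher number from compound 2 to compound 3 (0.42 log units; beyond the scatter). Since compound 1 sits at the limit (the limit of > 100000 nM in this assay, at which 1 of the 2 values shown sits), compound 3 is expected to give a value of about 80000 nM, within a range from 25000 nM to 200000 nM, with a fair chance that only a limit is reported.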

Compound 3, half-maximal inhibitory concentration: 40500 nM
Compound 3: middle estimate off by 2.0-fold (0.30 log units), on the high side, within the range that was stated.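

In this assay, exchanging 3,4-dichlorophenyl for 4-fluorophenyl on the saturated chain carbon gives a 1.3-fold higher number from compound 2 to compound 3 (0.12 log units; within the scatter), so the two groups cannot be told apart at this place and the 3,4-dichlorophenyl group is not required for a measurable value. The earlier step could be read as a penalty for any fluorophenyl group, but that reading does not hold: the exchange of 3-fluorophenyl for 4-fluorophenyl alone gives an at least 2.4-fold lower number from compound 1 to compound 3 (0.39 log units; beyond the scatter), which shows that the two fluorophenyl groups differ here. Compound 1 is therefore the one that stands apart among the three, and its value is a limit of the assay, not a number: the limit of > 100000 nM in this assay, at which 1 of the 3 values shown sits.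

On these data alone, whether a plain phenyl, a 4-chlorophenyl or a pyridine ring on the same chain carbon would group with compound 2 and compound 3 or with compound 1 remains open. Also open, as far as these compounds go, is how large the true gap to compound 1 is, since only a bound on that step can be read.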